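The compounds below may be only part of what the source reports. "The series", "measured", "known", "first", "only" and "open" are said of these compounds alone.

Measured compounds in a functional assay on B16-F10 cells (Mus musculus) for antiproliferative activity, read by CCK-8 assay, with a stated time of 48 h; on this read-out lower numbers stand for stronger inhibition and higher numbers for weaker inhibition:
Compound 1 `COc1ccc(/C=C\c2cc(OC)c(OC)c(OC)c2)cc1OCc1ccc(CNC(C)(C)C(=O)O)cc1`: compound 1 gives > 10000 nM, which is a limit of the assay and not a number.
Compound 2 `COc1ccc(/C=C\c2cc(OC)c(OC)c(OC)c2)cc1OCc1ccc(CN2CCCCC2C(=O)O)cc1`: compound 2 gives > 10000 nM, likewise a limit of the assay.
Compound 3 `COc1ccc(/C=C\c2cc(OC)c(OC)c(OC)c2)cc1OCc1ccc(CNCCO)cc1`: compound 3 gives 6600 nM.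

Compound 1 thus stands only at a limit in this assay, and two of the three values shown sit at that limit (the limit of > 10000 nM in this assay, at which 2 of the 3 values shown sit). The unmeasured compound 4 `COc1ccc(/C=C\c2cc(OC)c(OC)c(OC)c2)cc1OCc1ccc(CN2CCCCC2C(=O)NCCN)cc1` differs from compound 1 in one place: 2-((2-aminoethyl)carbamoyl)piperidin-1-yl in place of (1-carboxy-1-methylethyl)amino on a saturated chain carbon bound to an aromatic carbon.

Within the data shown here, two measured steps bear on it. The step from compound 1 to compound 2 exchanges the same (1-carboxy-1-methylethyl)amino group for 2-carboxypiperidin-1-yl, and the result is a step that the two limits leave unreadable from compound 1 to compound 2. Compound 2 carries the piperidine ring that compound 4 also carries; from there, an at least 1.5-fold lower number from compound 2 to compound 3 (0.18 log units; that floor lies within the scatter), and an at least 1.5-fold lower number from compound 1 to compound 3 (0.18 log units; that floor lies within the scatter) is of the same size, both floors lying within the scatter. Among the measured compounds shown here, compound 4 replaces the carboxy group of compound 2 by an aminoethyl carbamoyl group, a change no measured pair covers. No readable direction follows from the data; since compound 1 sits at a limit, the step to compound 4 can only be read as staying at the limit or reaching a number close to it.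

Compound 4 is therefore expected near the limit, the step of an at least 1.2-fold lower number from compound 1 to compound 4 (0.09 log units; that floor lies within the scatter) being an estimate only. Compound 4 is estimated at 8000 nM, in a range from 2500 nM to 30000 nM.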

Compound 4, half-maximal inhibitory concentration: 4600 nM
Beside the measured number, compound 4's estimate is 1.7-fold (0.24 log units) above it; low and high end bracket the measured number.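

In this assay, the position on a saturated chain carbon bound to an aromatic carbon now yields its first steps beyond the scatter: 2-((2-aminoethyl)carbamoyl)piperidin-1-yl in place of (1-carboxy-1-methylethyl)amino gives an at least 2.1-fold lower number from compound 1 to compound 4 (0.33 log units; beyond the scatter), and (2-aminoethyl)amino in place of hydroxy on a carbonyl carbon gives an at least 2.1-fold lower number from compound 2 to compound 4 (0.33 log units; beyond the scatter). The piperidine ring stands on both sides of the second change, so carrying that ring does not by itself hold a compound at the limit, while the comparison with the smaller (2-hydroxyethyl)amino group gives a 1.4-fold lower number from compound 3 to compound 4 (0.16 log units; within the scatter), which leaves those two compounds unseparated. The first two steps are floors, each starting from a limit of the assay: the limit of > 10000 nM in this assay, at which 2 of the 4 values shown sit.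

From the compounds shown here alone, what stays open is whether the terminal primary amine or the amide carbonyl carries the change, a question that a plain primary carboxamide, a 2-hydroxyethyl amide or a 3-aminopropyl amide on the same ring would address. Going by these compounds, how far the true values of compound 1 and compound 2 lie past their limits also remains unknown, so the full size of both floors cannot be read.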